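Ethyl to Isopropyl Urea Swap on Chlorobenzyl Core

The source may hold more compounds than are shown below. What is called first, only, known or untested is meant among the compounds shown, and "the series" means these compounds.

Compound 1 `CCNC(=O)N1CCN(C(=S)SCc2cn(Cc3ccccc3F)nn2)CC1` and compound 2 `CC(C)NC(=O)N1CCN(C(=S)SCc2cn(Cc3ccccc3F)nn2)CC1` share one core; in a functional assay on MGC-803 cells (Homo sapiens) for cytotoxicity, read by MTT assay, with a stated time of 72 h (a lower number here means a stronger inhibitor, a higher number a weaker inhibitor), compound 1 gives 2830 nM and compound 2 gives 1620 nM. The change between them is methyl in place of hydrogen on a saturated chain carbon bound to an amide-type nitrogen and a saturated chain carbon and the step it made is a 1.7-fold lower number from compound 1 to compound 2 (0.24 log units; within the scatter). Compound 3 `CCNC(=O)N1CCN(C(=S)SCc2cn(Cc3ccc(Cl)cc3)nn2)CC1` differs from compound 1 by 4-chlorophenyl in place of 2-fluorophenyl on a saturated chain carbon bound to an aromatic nitrogen; in this assay compound 3 gives 35400 nM, which is the step of a 13-fold higher number from compound 1 to compound 3 (1.10 log units; beyond the scatter) and the highest number among the three measured compounds. For the measured compounds named here, compound 4 `CC(C)NC(=O)N1CCN(C(=S)SCc2cn(Cc3ccc(Cl)cc3)nn2)CC1` has not yet been measured and differs from compound 3 by methyl in place of hydrogen on a saturated chain carbon bound to an amide-type nitrogen and a saturated chain carbon, the same change as the one separating compound 1 from compound 2, at a place described in identical words. The earlier step being within the scatter, the step expected in this assay is a 1.6-fold lower number from compound 3 to compound 4 (0.21 log units; within the scatter). Going by the values given here, compound 4 is therefore estimated at about 22000 nM, expected between 8000 nM and 60000 nM, the range kept wide because the only precedent a 1.7-fold lower number from compound 1 to compound 2 (0.24 log units; within the scatter) is itself within the scatter.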

Compound 4, half-maximal inhibitory concentration: 19900 nM
Compound 4: middle estimate off by 1.1-fold (0.04 log units), on the high side, within the range that was stated.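

In this assay, the ethyl to isopropyl change gives a 1.8-fold lower number from compound 3 to compound 4 (0.25 log units; within the scatter), and it carries from the core of compound 1 to the core of compound 3 with no measurable difference: the same change on two cores in this assay, a 1.7-fold lower number (0.24 log units; within the scatter) from compound 1 to compound 2 and a 1.8-fold lower number (0.25 log units; within the scatter) from compound 3 to compound 4, 1.0-fold (0.01 log units) apart, within the scatter of two such steps

The swap of 2-fluorophenyl for 4-chlorophenyl also carries over between the ethyl and isopropyl compounds, here as a 12-fold higher number from compound 2 to compound 4 (1.09 log units; beyond the scatter): the same change on two cores in this assay, a 13-fold higher number (1.10 log units; beyond the scatter) from compound 1 to compound 3 and a 12-fold higher number (1.09 log units; beyond the scatter) from compound 2 to compound 4, 1.0-fold (0.01 log units) apart, within the scatter of two such steps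

The two changes therefore read as independent across these four compounds, but both ethyl to isopropyl steps lie within the scatter, so their agreement does not show that the added methyl has a real effect, and only the aryl swap is a step beyond the scatter, seen on two cores in one assay.

The aryl swap alters the halogen and its ring place together, so the compounds shown do not say which of these goes with the large step. Also open, from the compounds shown here alone, is whether a longer chain such as butyl in place of isopropyl, or an unsubstituted phenyl in place of either halogenated ring, would follow the same steps.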